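A few compounds are considered here, and "the series" means these few. Any claim that something is new, unique, unknown or untested is made for them only; others in the source may bear on it.

The shared core carries an aromatic ester, and this is where the two measured compounds differ. Compound 1 `CC1=CC[C@H]2[C@H](CC[C@]2(C)O)C(C)(C)[C@@H]1CC[C@H]1[C@]2(C)CC[C@H](OC(=O)c3ccc(C)cc3)C(C)(C)O[C@H]2CC[C@@]1(C)O` gives 33400 nM in a functional assay on MDA-MB-231 cells (Homo sapiens) for antiproliferative activity, read by MTT assay, with a stated time of 72 h; on this read-out lower numbers stand for stronger inhibition and higher numbers for weaker inhibition. Compound 2 `CC1=CC[C@H]2[C@@H]1CC=C(C)[C@@H](CC[C@H]1[C@]3(C)CC[C@H](OC(=O)c4ccncc4)C(C)(C)O[C@H]3CC[C@@]1(C)O)C2(C)C` gives 19100 nM in this assay. The two numbers lie within the usual scatter of one another, so compound 1 cannot be set apart from compound 2 on these data, and both sit in a weak range. Compound 3 `CC1=CC[C@H]2[C@H](CC[C@]2(C)O)C(C)(C)[C@@H]1CC[C@H]1[C@]2(C)CC[C@H](OC(=O)c3cccc(C(F)(F)F)c3)C(C)(C)O[C@H]2CC[C@@]1(C)O` has not yet been measured. It differs from compound 1 in a single place: 3-(trifluoromethyl)phenyl in place of 4-methylphenyl on a carbonyl carbon. Going by the values given here, no measured pair in this set shows what such an exchange on the carbonyl carbon does. The step of a 1.3-fold lower number from compound 1 to compound 3 (0.13 log units; within the scatter) is expected to stay within the scatter, with no clear direction. Compound 3 is therefore estimated at 25000 nM in this assay, with a range from 8000 nM to 80000 nM.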

Compound 3, half-maximal inhibitory concentration: 36300 nM
Beside the measured number, compound 3's estimate is 1.5-fold (0.16 log units) below it, and the stated range covers the measured number.
By their numbers in this assay, from the lowest: compounds 2, 1 and 3 (each within the scatter of the next).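

In this assay, going by these compounds alone, 3-(trifluoromethyl)phenyl in place of 4-methylphenyl on the carbonyl carbon gives a 1.1-fold higher number from compound 1 to compound 3 (0.04 log units; within the scatter), the only single-place step at this position in the set. The position therefore accepts an aromatic group of 10 heavy atoms, carrying fluorine, in place of one of 7 heavy atoms without a difference that can be told from the scatter, and compound 1 and compound 3 both lie in a weak range. Nothing shown here accounts for this result.

Because both groups are carbon-only aromatic rings, the compounds shown leave open whether any group on this carbonyl carbon can move the number beyond the scatter. From the compounds shown here alone, what an amine or a carboxylic acid on the aromatic ring would do remains unknown, as does the effect of a longer alkyl chain in place of the ring.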